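The source may report more compounds than this note shows. Statements on the series, on what has been measured and on what is new or still open speak of the compounds shown alone.

Measured so far in an assay on isolated protein for inhibition of cathepsin S (Homo sapiens), read by fluorescence; a higher number here means a weaker inhibitor, a lower number a stronger inhibitor:
- compound 1, `Cn1cnc2c(C#N)nc(-c3ccc(OCc4cccnc4)c(C(F)(F)F)c3)cc21`: 12.6 nM
- compound 2, `Cn1cnc2c(C#N)nc(-c3ccc(OCc4ccncc4)c(C(F)(F)F)c3)cc21`: 10 nM
- compound 3, `Cn1cnc2c(C#N)nc(-c3ccc(OC4CCNCC4)c(C(F)(F)F)c3)cc21`: 316 nM

Compound 3 gives the highest number of the three. The two steps leading to it are both large: a 25-fold higher number from compound 1 to compound 3 (1.40 log units; beyond the scatter) and a 32-fold higher number from compound 2 to compound 3 (1.50 log units; beyond the scatter). The step between the two lower compounds, a 1.3-fold lower number from compound 1 to compound 2 (0.10 log units; within the scatter), stays within the scatter, so the rise to compound 3 is tied to exchanging a (pyridinyl)methyl group for piperidin-4-yl on the aromatic oxygen.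

Compound 4, `CN(C)CCCOc1ccc(-c2cc3c(ncn3C)c(C#N)n2)cc1C(F)(F)F`, is built from compound 3 by the change (3-(dimethylamino)propyl in place of piperidin-4-yl on an oxygen on an aromatic ring). For the measured compounds named here, no measured pair covers a move from a saturated ring to an open chain on this oxygen, so the measured steps bear on compound 4 only indirectly: they show that this position is sensitive and that compound 3 holds the weak end of the series. Since the new group keeps one acceptor but drops the donor and the ring, compound 4 is expected to differ from compound 3 by a 2.1-fold lower number from compound 3 to compound 4 (0.32 log units; beyond the scatter) in this assay, with wide uncertainty in either direction. The value of compound 4 in this assay is estimated at 150 nM, within a range of 40 nM to 600 nM.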

Compound 4, half-maximal inhibitory concentration: 41 nM
Compound 4: the middle estimate sits 3.7-fold (0.56 log units) above what was measured; the range from low to high includes it.
By their numbers in this assay, from the lowest: compounds 2 and 1 (each within the scatter of the next); then compound 4; then compound 3.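

In this assay, the open 3-(dimethylamino)propyl chain on the aromatic oxygen gives a 7.7-fold lower number from compound 3 to compound 4 (0.89 log units; beyond the scatter), so the high number of compound 3 does not extend to every group at this place that carries a saturated nitrogen, and the position tolerates a ring-free chain better than it tolerates piperidin-4-yl. The chain still does not match the pyridine-bearing groups, as shown by a 4.1-fold higher number from compound 2 to compound 4 (0.61 log units; beyond the scatter) and by a 3.3-fold higher number from compound 1 to compound 4 (0.51 log units; beyond the scatter), which places the open amine in an intermediate position among the groups compared on this oxygen. No available evidence speaks to the reason for this ordering.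

The change from compound 3 to compound 4 removes the ring and the hydrogen-bond donor together, so the compounds shown leave open which of the two goes with the lower number, a question that a 1-methylpiperidin-4-yl group on the same oxygen would bear on. They also leave open how the number depends on chain length and on the end group, as would be tested by a shorter 2-(dimethylamino)ethyl chain, a longer chain ending in the same amine, or a chain ending in a carboxylic acid.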